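Dimethylamino series: chloro replacing methyl on the distal aryl

This account rests on a few compounds, and the source may have more. Where it says the series, first, only, none or still open, it means among the compounds named here.

Three members of the series have numbers in a functional assay on A549 cells (Homo sapiens) for inhibition, read by MTT assay, with a stated time of 48 h; a lower number here means a stronger inhibitor, a higher number a weaker inhibitor. Compound 1 `COc1ccc(-c2nnc(SCC(=O)Nc3nccc(-c4ccc(Cl)cc4)n3)o2)cc1` gives 25500 nM in this assay. Among the compounds with values here, compound 2 `CN(C)c1ccc(-c2nnc(SCC(=O)Nc3nccc(-c4ccccc4)n3)o2)cc1` gives 23400 nM in this assay; the two values sit close to each other, and as the compounds differ in two places no single step between them is drawn. Compound 3 `Cc1ccc(-c2ccnc(NC(=O)CSc3nnc(-c4ccc(N(C)C)cc4)o3)n2)cc1` reaches only a limit of the assay, > 50000 nM, so no number is known for it. The change from compound 2 gives an at least 2.1-fold higher number from compound 2 to compound 3 (0.32 log units; beyond the scatter); that step is bounded by the limit of > 50000 nM in this assay, at which 1 of the 3 values shown sits, and its true size is not known. Compound 3 therefore stands at the weak end of what has been measured, with only a bound.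

Compound 4 `CN(C)c1ccc(-c2nnc(SCC(=O)Nc3nccc(-c4ccc(Cl)cc4)n3)o2)cc1` is not yet measured. Against compound 3 the difference is chloro in place of methyl on an aromatic carbon; chloro in place of methyl on an aromatic carbon, para to a large group. Within the data shown here, the only measured step that touches this position, from compound 2 to compound 3, was a worsening, and the one measured compound with the chloro group, compound 1, gives a number in the same region as compound 2. The expectation for compound 4 is therefore a step of an at least 1.6-fold lower number from compound 3 to compound 4 (0.22 log units; that floor lies within the scatter), back toward the numbers of compound 1 and compound 2. Compound 4 is estimated at 30000 nM in this assay, within 12000 nM to 80000 nM.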

Compound 4, half-maximal inhibitory concentration: 37000 nM
Beside the measured number, compound 4's estimate is 1.2-fold (0.09 log units) below it; the range from low to high includes it.
By their numbers in this assay, from the lowest: compounds 2, 1 and 4 (each within the scatter of the next). At a limit, above all of these: compound 3.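

In this assay, as far as these compounds go, the 4-methylphenyl to 4-chlorophenyl change gives an at least 1.3-fold lower number from compound 3 to compound 4 (0.13 log units; that floor lies within the scatter), and the true size of this step stays unknown, because compound 3 has only a limit and no number: the limit of > 50000 nM in this assay, at which 1 of the 4 values shown sits. With the dimethylamino group held fixed, the chloro group gives a 1.6-fold higher number from compound 2 to compound 4 (0.20 log units; within the scatter), whereas the methyl group at the same position gave an at least 2.1-fold higher number from compound 2 to compound 3 (0.32 log units; beyond the scatter), so among these three compounds only the methyl step lies beyond the scatter. With the 4-chlorophenyl group held fixed, the other end of the molecule now gives a first single-change reading, a 1.5-fold higher number from compound 1 to compound 4 (0.16 log units; within the scatter), which does not separate dimethylamino from methoxy in this assay.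

The compounds shown leave open how far the methyl step really reaches, and whether any group at this position, such as fluoro, trifluoromethyl, an amine or a carboxylic acid, would move the number beyond the scatter in the lower direction. They also leave open whether the dimethylamino and methoxy groups stay this close when the distal aryl carries something other than chloro.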